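This account rests on a few compounds, and the source may have more. Where it says the series, first, only, none or still open, it means among the compounds named here.

Measured in a functional assay on HeLa cells (Homo sapiens) for inhibition; a higher number here means a weaker inhibitor, a lower number a stronger inhibitor:
compound 1 `O=C1C=CC(OCC(F)(F)F)N1c1ccc(C(F)(F)F)cc1`: 36200 nM.
compound 2 `O=C1C=CC(OCC(F)(F)F)N1c1ccccc1`: > 100000 nM, a limit of the assay rather than a number.
compound 3 `O=C1C=CC(OCC(F)(F)F)N1c1ccc([N+](=O)[O-])cc1`: 2380 nM.

Compound 3 holds the lowest of the two numbers; its nearest neighbour is compound 1, with a 15-fold lower number from compound 1 to compound 3 (1.18 log units; beyond the scatter). Compound 4 `CC(C)(C)c1ccc(N2C(=O)C=CC2OCC(F)(F)F)cc1` differs from compound 3 by tert-butyl in place of nitro on an aromatic carbon. Among the measured compounds shown here, the steps that bear on it both run toward the nitro: an at least 42-fold lower number from compound 2 to compound 3 (1.62 log units; beyond the scatter) and a 15-fold lower number from compound 1 to compound 3 (1.18 log units; beyond the scatter), each large, while an at least 2.7-fold higher number from compound 1 to compound 2 (0.44 log units; beyond the scatter) is at least modest. Replacing the nitro with tert-butyl reverses these steps, so a large higher number is expected, and one cannot rule out that only a limit is reported. The expected step is a 21-fold higher number from compound 3 to compound 4 (1.32 log units; beyond the scatter). For compound 4 the estimate in this assay is 50000 nM, within 12000 nM to 200000 nM.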

Compound 4, half-maximal inhibitory concentration: 18100 nM
Estimate against measurement, compound 4: 2.8-fold (0.44 log units) above; low and high end bracket the measured number.
By their numbers in this assay, from the lowest: compound 3; then compounds 4 and 1 (each within the scatter of the next). At a limit, above all of these: compound 2.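

Compound 2, with hydrogen at this position, stands at a limit of the assay and not at a number: the limit of > 100000 nM in this assay, at which 1 of the 4 values shown sits.

Nitro is not alone in moving away from that limit: tert-butyl, which enters with no hydrogen-bond acceptors, gives an at least 5.5-fold lower number from compound 2 to compound 4 (0.74 log units; beyond the scatter), yet the change from nitro still costs, with a 7.6-fold higher number from compound 3 to compound 4 (0.88 log units; beyond the scatter). Tert-butyl and trifluoromethyl cannot be told apart, with a 2.0-fold lower number from compound 1 to compound 4 (0.30 log units; within the scatter).

On these data alone, whether the lower number of compound 3 is peculiar to nitro stays open, since a nitrile, an amine or a carboxylic acid at this position could test it.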